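A Methyl-to-Trifluoromethyl Swap on the Nitrogen-Containing Ring

The source may hold more compounds than are shown below. What is called first, only, known or untested is meant among the compounds shown, and "the series" means these compounds.

Compound 3 `Cc1ccnc(Oc2ccc(CC3SC(=O)NC3=O)cc2)c1` was tested in a functional assay for agonist activity at Free fatty acid receptor 1 (Homo sapiens), read by FLIPR, in the presence of a further agent that is not named here (a higher number here means that more compound is needed for the effect, a lower number that less compound is needed), where compound 3 gives 4280 nM, the highest of the three numbers seen so far. Its nearest neighbour is compound 2 `Cc1cccc(Oc2ccc(CC3SC(=O)NC3=O)cc2)n1`, which gives 2620 nM; the step of a 1.6-fold higher number from compound 2 to compound 3 (0.21 log units; within the scatter) lies within the scatter. Compound 1 `Cc1ccc(C)c(Oc2ccc(CC3SC(=O)NC3=O)cc2)c1` gives 238 nM, a difference from compound 3 that is beyond the scatter. Compound 4 `O=C1NC(=O)C(Cc2ccc(Oc3cc(C(F)(F)F)ccn3)cc2)S1` differs from compound 3 by trifluoromethyl in place of methyl on an aromatic carbon. Within the data shown here, no measured step exchanges a methyl for a trifluoromethyl, so nothing directly informs this change; the only single-point step, moving the methyl on the same ring, stayed within the scatter. A step within the scatter is therefore expected. The expected step is a 1.7-fold lower number from compound 3 to compound 4 (0.23 log units; within the scatter). Compound 4 is estimated at 2500 nM, with a range from 900 nM to 7000 nM.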

Compound 4, half-maximal effective concentration: 237 nM
Compound 4: middle estimate off by 11-fold (1.02 log units), on the high side, and the stated range ends above it.
By their numbers in this assay, from the lowest: compounds 4 and 1 (each within the scatter of the next); then compounds 2 and 3 (each within the scatter of the next).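

Among these compounds, at this aromatic carbon, opposite the ring nitrogen, the identity of the group matters far more than the earlier compounds suggested: in this assay, trifluoromethyl in place of methyl gives a large change (an 18-fold lower number from compound 3 to compound 4 (1.26 log units; beyond the scatter)). Moving the methyl had stayed within the scatter (a 1.6-fold higher number from compound 2 to compound 3 (0.21 log units; within the scatter)), so that step gave no hint of this sensitivity. Nothing measured here gives a reason for the drop. Going by these compounds, it remains open how a chlorine, a nitrile or a methoxy would read at this carbon, and whether trifluoromethyl would produce a similar step in place of the methyl of compound 2.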